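Chloro for methoxy on the benzyl of a trimethoxybenzylidene oxindole

The compounds below may be only part of what the source reports. "The series", "measured", "known", "first", "only" and "open" are said of these compounds alone.

Compound 1 `COc1ccc(CN2C(=O)/C(=C\c3cc(OC)c(OC)c(OC)c3)c3ccccc32)cc1` and compound 2 `COc1cc(/C=C2\C(=O)N(C)c3ccc(Cl)cc32)cc(OC)c1OC` are the measured members of the series. In a functional assay on cells (Cancer cell lines, Homo sapiens) for cytotoxicity, with a stated time of 48 h (on this read-out lower numbers stand for stronger inhibition of growth and higher numbers for weaker inhibition of growth), compound 1 gives 2700 nM and compound 2 gives 3200 nM; the two numbers lie within the scatter of each other, so no order between them can be read. Compound 3 `COc1cc(/C=C2\C(=O)N(Cc3ccc(Cl)cc3)c3ccccc32)cc(OC)c1OC` is not yet measured. It differs from compound 1 by chloro in place of methoxy on an aromatic carbon. Among the compounds with values here, no measured pair shows this change, so the expectation rests on compound 1 alone: a step of a 1.1-fold lower number from compound 1 to compound 3 (0.03 log units; within the scatter) is expected, not beyond the scatter in either direction. Compound 3 is estimated at 2500 nM, within 1000 nM to 6000 nM.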

Compound 3, concentration for 50% growth inhibition: 2200 nM
The estimate for compound 3 lay 1.1-fold (0.06 log units) above the measured number, within the range that was stated.
By their numbers in this assay, from the lowest: compounds 3, 1 and 2 (each within the scatter of the next).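

In this assay the change from 4-methoxybenzyl to 4-chlorobenzyl gives a 1.2-fold lower number from compound 1 to compound 3 (0.09 log units; within the scatter) and so does not separate chloro from methoxy at this aromatic carbon, para to a large group. Here the read-out stays within the scatter when the methoxy and its hydrogen-bond acceptor leave. No measurement on hand explains this result.

Still open, from the compounds shown here alone, is whether an amine or a carboxylic acid on this aromatic carbon would move the number beyond the scatter. Also open, going by these compounds, is how a longer chain in place of the 4-chlorobenzyl would read.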